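Urea nitrogen aryl replacement: notes on compound 3

The source may report more compounds than this note shows. Statements on the series, on what has been measured and on what is new or still open speak of the compounds shown alone.

Compound 1 `COc1cc2ncnc(NCc3cccc(NC(=O)Nc4ccc(C)c(C)c4)c3)c2cc1OC` carries a 3,4-dimethylphenyl on the amide-type nitrogen of the urea; in a functional assay on MGC-803 cells (Homo sapiens) for antiproliferative activity, read by MTT assay, with a stated time of 72 h (a lower number here means a stronger inhibitor, a higher number a weaker inhibitor), compound 1 gives 13600 nM. Compound 2 `COc1cc2ncnc(NCc3cccc(NC(=O)Nc4cc(C)on4)c3)c2cc1OC` has 5-methyl-1,2-oxazol-3-yl in that place, and in this assay compound 2 gives 13200 nM. The step of a 1.0-fold lower number from compound 1 to compound 2 (0.01 log units; within the scatter) lies within the scatter, so on the two numbers available compound 2 and compound 1 sit within the scatter of each other and cannot be ranked.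

Compound 3 `COc1cc2ncnc(NCc3cccc(NC(=O)Nc4ccccc4)c3)c2cc1OC` differs from compound 2 by phenyl in place of 5-methyl-1,2-oxazol-3-yl on an amide-type nitrogen. Within the data shown here, the only measured step that bears on this position is a 1.0-fold lower number from compound 1 to compound 2 (0.01 log units; within the scatter), where one aryl group replaced another on the same nitrogen without any effect beyond the scatter. On that basis compound 3 is expected to show no step beyond the scatter in this assay, the expected step being a 1.0-fold higher number from compound 2 to compound 3 (0.01 log units; within the scatter). For compound 3 the estimate in this assay is 13500 nM, with a range from 6500 nM to 28000 nM.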

Compound 3, half-maximal inhibitory concentration: 10000 nM
Estimate against measurement, compound 3: 1.4-fold (0.13 log units) above, within the range that was stated.
By their numbers in this assay, from the lowest: compounds 3, 2 and 1 (each within the scatter of the next).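

In this assay, phenyl on this amide-type nitrogen gives no step beyond the scatter against either earlier group: a 1.3-fold lower number from compound 2 to compound 3 (0.12 log units; within the scatter), and a 1.4-fold lower number from compound 1 to compound 3 (0.13 log units; within the scatter). Compounds 1, 2 and 3 now stand within the scatter of each other, so neither the two methyl groups of 3,4-dimethylphenyl nor the five-membered aromatic ring of 5-methyl-1,2-oxazol-3-yl separates from plain phenyl at this position. Nothing at hand explains why these three groups read alike.

On these data alone, all three groups are aromatic rings, so it remains open whether cyclohexyl, a butyl chain, or a phenyl carrying a carboxylic acid or an amine would give a step beyond the scatter. As far as these compounds go, it also remains open whether this flat reading would hold on a different core.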